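This account rests on a few compounds, and the source may have more. Where it says the series, first, only, none or still open, it means among the compounds named here.

Measured compounds:
compound 1 `O=C(Nc1cccc(-n2cc(-c3ccncc3)c(-c3cc(O)cc(Cl)c3)n2)c1)Nc1ccc(Cl)c(C(F)(F)F)c1` — 47.6%
compound 2 `COc1cc(Cl)cc(-c2nn(-c3cccc(NC(=O)Nc4ccc(Cl)c(C(F)(F)F)c4)c3)cc2-c2ccncc2)c1` — 9.81%
compound 3 `O=C(Nc1cccc(-n2cc(-c3ccncc3)c(-c3cc(O)cc(Cl)c3)n2)c1)c1cc(C(F)(F)F)cc(C(F)(F)F)c1` — 73.4%

Three compounds have been run in a functional assay on BT-549 cells (Homo sapiens) for inhibition, read by sulforhodamine B assay, with a stated time of 48 h, tested at 10 uM; on this read-out lower numbers stand for a stronger effect and higher numbers for a weaker effect at the one concentration tested. Compound 1 and compound 2 share one core and differ in a single place: methyl in place of hydrogen on an oxygen on an aromatic ring. That change made the step of a number 37.8 percentage points lower from compound 1 to compound 2 (beyond the scatter), so compound 2 sits well below compound 1 on this read-out.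

Compound 3 carries a different core. How the core of compound 3 differs from the core of compound 1 is not broken down here; on this read-out compound 3 stands highest of the three, and its nearest neighbour is compound 1.

Compound 4 `COc1cc(Cl)cc(-c2nn(-c3cccc(NC(=O)c4cc(C(F)(F)F)cc(C(F)(F)F)c4)c3)cc2-c2ccncc2)c1` has not yet been measured. It differs from compound 3 in one place: methyl in place of hydrogen on an oxygen on an aromatic ring. This is the same change as the one from compound 1 to compound 2, made on the same place, and it occurs twice among the compounds shown.

The expectation for compound 4 rests on that one earlier step. Since compound 3 gives 73.4% in this assay, and because the matching change gave a number 37.8 percentage points lower from compound 1 to compound 2 (beyond the scatter), a step of about a number 35.4 percentage points lower from compound 3 to compound 4 (beyond the scatter) is expected for compound 4. Going by the values given here, with only one prior example, on a different core, the range around this estimate is kept wide. Compound 4 is therefore estimated at 38% in this assay, between 15% and 65%.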

Compound 4, a percentage reported as activity, at one concentration (the size of the read-out at that concentration, not a potency): 96.8%
Compound 4: middle estimate off by 58.8 percentage points, on the low side; the measured number lies above the stated range.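

In this assay, the change from hydroxy to methoxy on the aromatic ring did not carry over from one core to the other, and the two steps ran in opposite directions: the same change on two cores in this assay, a number 37.8 percentage points lower (beyond the scatter) from compound 1 to compound 2 and a number 23.4 percentage points higher (beyond the scatter) from compound 3 to compound 4, 61.2 percentage points apart, beyond the scatter of two such steps

On the core of compound 3 the change gave a number 23.4 percentage points higher from compound 3 to compound 4 (beyond the scatter), so the size and even the direction of the earlier step could not be transferred to this core. This shows that, for these two pairs, the outcome of the change depends on the core that carries it, but two pairs give no rule for the series and do not show why the cores respond differently.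

The compounds shown leave open which part of the two cores sets the direction of the step, since the core of compound 1 and the core of compound 3 are not separated here by any pair that differs in one place. On these data alone, it also remains open how an ethyl group or a longer chain on that oxygen, or an amine in place of the hydroxy group, would behave on either core.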